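Shortening the Carbonate Chain: Compound 1 to Compound 4

This account rests on a few compounds, and the source may have more. Where it says the series, first, only, none or still open, it means among the compounds named here.

Compound 1 `CCCOC(=O)OCC(CO)CCn1cnc2cnc(N)nc21` was measured in an ADME assay for pharmacokinetics, read by HPLC, at 37 degrees C, at pH 1.2 (on this read-out higher numbers stand for a longer-lived compound and lower numbers for a shorter-lived compound), and gives 696 h. It stands level with compound 3 `CCCCOC(=O)OCC(CO)CCn1cnc2cnc(N)nc21`, which gives 696 h, the two together being the highest of the three numbers; compound 2 `CCCCCOC(=O)OCC(CO)CCn1cnc2cnc(N)nc21` gives 600 h. Compound 4 `CCOC(=O)OCC(CO)CCn1cnc2cnc(N)nc21` differs from compound 1 in one place: hydrogen in place of methyl on a saturated chain carbon, two bonds along the chain from an oxygen next to a carbonyl group. Two measured steps on the same chain bear on this: no change at the digits printed from compound 1 to compound 3 (within the scatter) and a 1.2-fold lower number from compound 1 to compound 2 (0.06 log units; within the scatter), both within the scatter. Since lengthening this chain moved nothing beyond the scatter, the shortening in compound 4 is expected to move nothing either, and the step of a 1.0-fold lower number from compound 1 to compound 4 (0.00 log units; within the scatter) is expected to stay within the scatter. Compound 4 is therefore estimated at 690 h, with a range from 400 h to 1200 h.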

Compound 4, half-life: 840 h
Estimate against measurement, compound 4: 1.2-fold (0.09 log units) below, and the stated range covers the measured number.
By their numbers in this assay, from the lowest: compounds 2, 1, 3 and 4 (each within the scatter of the next).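

Going from propyl to ethyl at this position leaves the number within the scatter in this assay: a 1.2-fold higher number from compound 1 to compound 4 (0.08 log units; within the scatter), and the two longer chains read the same way, a 1.2-fold higher number from compound 3 to compound 4 (0.08 log units; within the scatter) and a 1.4-fold higher number from compound 2 to compound 4 (0.15 log units; within the scatter). Even the shortest and longest chains shown therefore stay within the scatter of each other. Removing one carbon also reads alike at two chain lengths: the same change on two cores in this assay, a 1.2-fold higher number (0.06 log units; within the scatter) from compound 2 to compound 3 and a 1.2-fold higher number (0.08 log units; within the scatter) from compound 1 to compound 4, 1.0-fold (0.02 log units) apart, within the scatter of two such steps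

From the compounds shown here alone, whether a branched chain or a chain ending in an amine would shift the half-life remains open. So does how these compounds behave at a different pH.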